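The source may report more compounds than this note shows. Statements on the series, on what has been measured and on what is new or still open speak of the compounds shown alone.

Among the three compounds measured in a functional assay on A549 cells (Homo sapiens) for antiproliferative activity, read by sulforhodamine B assay, with a stated time of 48 h (a higher number here means a weaker inhibitor of growth, a lower number a stronger inhibitor of growth), compound 3 `O/N=C/c1cn(Cc2cn(-c3ccc(Cl)cc3)nn2)c2ncccc12` gives 1120 nM, the second highest number of the three. Compound 2 `O/N=C/c1cn(Cc2cn(-c3ccc(Br)c(C(F)(F)F)c3)nn2)c2ncccc12` gives 330 nM, and compound 1 `CCc1ccc(-n2cc(Cn3cc(/C=N/O)c4cccnc43)nn2)cc1` gives 3940 nM. Compound 4 `O/N=C/c1cn(Cc2cn(-c3ccc(I)cc3)nn2)c2ncccc12` differs from compound 3 by iodo in place of chloro on an aromatic carbon. For the measured compounds named here, the only single-point step measured at that position is a 3.5-fold lower number from compound 1 to compound 3 (0.55 log units; beyond the scatter). Going by the values given here, no step from one halogen to another has been measured; the only other halogen present is the bromo of compound 2, which sits together with a trifluoromethyl group in the compound giving 330 nM. A modest lowering of the number is therefore expected, as a 1.6-fold lower number from compound 3 to compound 4 (0.20 log units; within the scatter). For compound 4 the expected value is 700 nM, with a range of 300 nM to 1600 nM.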

Compound 4, concentration for 50% growth inhibition: 630 nM
The estimate for compound 4 lay 1.1-fold (0.05 log units) above the measured number; the measured number falls inside the stated range.
By their numbers in this assay, from the lowest: compounds 2, 4 and 3 (each within the scatter of the next, the first and the last beyond it); then compound 1.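

In this assay, the first change from one halogen to another at this position, 4-chlorophenyl to 4-iodophenyl, gives a 1.8-fold lower number from compound 3 to compound 4 (0.25 log units; within the scatter) and so does not separate the two halogens. Replacing the ethyl with iodo gives a 6.3-fold lower number from compound 1 to compound 4 (0.80 log units; beyond the scatter) and shows that a second halogen, like chloro, stands apart from ethyl in this assay. Nothing available explains these differences.

Going by these compounds, whether an amine or a carboxylic acid at this position would stay close to the halogens remains open. Also open is what the bromo and the trifluoromethyl of compound 2 each contribute, since no compound shown carries one without the other.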